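A Single Fluoro Added to a Compound at the Limit

The source may report more compounds than this note shows. Statements on the series, on what has been measured and on what is new or still open speak of the compounds shown alone.

Of the compounds shown here, two in this small set have been tested for antiproliferative activity so far. In a functional assay on HT-29 cells (Homo sapiens) for antiproliferative activity, read by sulforhodamine B assay, with a stated time of 48 h (a lower number here means a stronger inhibitor, a higher number a weaker inhibitor), compound 1 `CCN1CCN(c2ccc(S(=O)(=O)Oc3cccc(F)c3)cc2)C1=O` gives > 100000 nM, which is a limit of the assay and not a number. Compound 2 `CCCCN1CCN(c2ccc(S(=O)(=O)Oc3ccccc3)cc2)C1=O` gives > 100000 nM, and this too is only a limit of the assay. Compound 2 therefore has no numerical value, and the only other result beside it is also a limit. For the measured compounds named here, no measured step is available to serve as a guide.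

The next compound, compound 3 `CCCCN1CCN(c2ccc(S(=O)(=O)Oc3cccc(F)c3)cc2)C1=O`, differs from compound 2 by a single change, (fluoro in place of hydrogen on an aromatic carbon). This places fluoro in place of hydrogen on an aromatic carbon, turning phenoxy into 3-fluorophenoxy, while the rest of the structure stays the same.

With no numerical value to build on, no change beyond the scatter is expected in this assay, and so no direction is predicted. The expected change is a number no higher from compound 2 to compound 3 (the limit leaves the size open). Compound 3 is estimated at 100000 nM, with an expected range of 40000 nM to 150000 nM.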

Compound 3, half-maximal inhibitory concentration: 76000 nM
Beside the measured number, compound 3's estimate is 1.3-fold (0.12 log units) above it; the measured number falls inside the stated range.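

In this assay, fluoro in place of hydrogen on an aromatic carbon, turning phenoxy into 3-fluorophenoxy, gives an at least 1.3-fold lower number from compound 2 to compound 3 (0.11 log units; that floor lies within the scatter), while ethyl in place of hydrogen on a saturated chain carbon gives an at least 1.3-fold lower number from compound 1 to compound 3 (0.11 log units; that floor lies within the scatter). For the compounds shown here, compound 3, which carries both the 3-fluorophenoxy group and that added ethyl, gives 76000 nM, the first number and a first reading of this position that the earlier compounds could not provide. Neither step establishes a change beyond the scatter, and the true size of each stays unknown because each starts from a limit of the assay: the limit of > 100000 nM in this assay, at which 2 of the 3 values shown sit.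

The compounds shown leave open whether chloro, methoxy or an amine in place of the fluoro would give a lower number than compound 3 does, and whether fluoro elsewhere on the same ring would do so. They also leave open how a longer chain on the ring nitrogen would compare with the chain of compound 3, so neither the ring position nor the chain can yet be ranked.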